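A Small Methoxy-Bearing Chain in Place of the Benzylic Alcohol

The compounds below may be only part of what the source reports. "The series", "measured", "known", "first", "only" and "open" are said of these compounds alone.

compound 1 `CC(C)CC1n2cncc2CN(CC2CC2)S1(=O)=O`: 19%
compound 2 `C[C@@H](c1ccc(Cl)cc1)N1Cc2cncn2C(C[C@@H](O)c2ccccc2)S1(=O)=O`: 6%
compound 3 `CC(C)CC1n2cncc2CN([C@H](C)c2ccc(Cl)cc2)S1(=O)=O`: 24%

In an assay on isolated protein for inhibition of Aromatase (Homo sapiens), tested at 1 uM (a lower number here means less inhibition, a higher number more inhibition at the concentration tested (going by the name of the read-out)), compound 2 stands lowest of the three numbers; compound 1 is its nearest neighbour and compound 3 its furthest, and both gaps lie beyond the scatter. Compound 4 `COC(C)(C)CC1n2cncc2CN([C@@H](C)c2ccc(Cl)cc2)S1(=O)=O` is reached from compound 2 by 1-methoxy-1-methylethyl in place of hydroxy(phenyl)methyl on a saturated chain carbon bound to a saturated ring carbon. Going by the values given here, no two measured compounds differ in one place only, so the size of this step has no measured counterpart. Compound 3 gives 24% in this assay and compound 1 gives 19%, and compound 4 shares with compound 3 the rest of its structure. The step of a number 14 percentage points higher from compound 2 to compound 4 (beyond the scatter) is therefore expected upward and beyond the scatter. Compound 4 is estimated at 20%, within 8% to 34%.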

Compound 4, a percentage reported as inhibition, at one concentration (the size of the read-out at that concentration, not a potency): 17%
Estimate against measurement, compound 4: 3 percentage points above; the measured number falls inside the stated range.
By their numbers in this assay, from the lowest: compound 2; then compounds 4, 1 and 3 (each within the scatter of the next).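

In this assay, 1-methoxy-1-methylethyl in place of hydroxy(phenyl)methyl gives a number 11 percentage points higher from compound 2 to compound 4 (beyond the scatter) on a saturated chain carbon bound to a saturated ring carbon. This is the only one-place comparison shown, and it establishes that the number responds to the group at this position. The change removes the six-membered aromatic ring and the hydrogen-bond donor together, so their shares cannot be separated. Nothing measured here accounts for the step. As far as these compounds go, it remains open whether a plain 2-phenylethyl chain, an amine or a carboxylic acid at this position would read higher or lower.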